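The compounds below may be only part of what the source reports. "The series", "measured", "known", "first", "only" and "open" are said of these compounds alone.

Working notes on the series. Compound 1 `Cc1ccc(-c2cc(N)n(-c3ccc(Br)cc3)n2)cc1` gives 45000 nM in a functional assay on Jurkat cells (Homo sapiens) for inhibition, read by MTT assay, with a stated time of 72 h (on this read-out higher numbers stand for weaker inhibition of growth and lower numbers for stronger inhibition of growth), the lower of the two numbers obtained. Compound 2 `Nc1cc(-c2ccc(Cl)cc2)nn1-c1ccc(Br)cc1` gives 61300 nM in this assay, and a 1.4-fold higher number from compound 1 to compound 2 (0.13 log units; within the scatter). Compound 3 `Cc1ccc(-c2cc(/N=C/N(C)C)n(-c3ccc(Br)cc3)n2)cc1` reaches only a limit of this assay, > 100000 nM. The step of an at least 2.2-fold higher number from compound 1 to compound 3 (0.34 log units; beyond the scatter) rests on (the limit of > 100000 nM in this assay, at which 1 of the 3 values shown sits), so its true size is open.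

Compound 4 `Cc1ccc(-c2nn(-c3ccc(Br)cc3)c(N)c2C=O)cc1` is not yet measured. It differs from compound 1 by formyl in place of hydrogen on an aromatic carbon. Among the compounds with values here, no measured step puts a group at this carbon; the nearest comparison is the change at the amino group from compound 1 to compound 3, where the number rose beyond the scatter, while the change from compound 1 to compound 2 on the distant aryl ring stayed within it. The formyl enters the ring position next to the amino group, so a modest rise in the number is expected rather than none. The step of a 1.4-fold higher number from compound 1 to compound 4 (0.16 log units; within the scatter) is the estimate. Compound 4 is expected at 65000 nM, within 22000 nM to 190000 nM.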

Compound 4, concentration for 50% growth inhibition: 34400 nM
Beside the measured number, compound 4's estimate is 1.9-fold (0.28 log units) above it; measured number inside the range.
By their numbers in this assay, from the lowest: compounds 4, 1 and 2 (each within the scatter of the next). At a limit, above all of these: compound 3.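

In this assay, within the data shown here, formyl in place of hydrogen gives a 1.3-fold lower number from compound 1 to compound 4 (0.12 log units; within the scatter), the first measured step at this carbon, which lies next to the ring atom that bears an amino group and next to the ring atom that bears a 4-methylphenyl group. The assay therefore does not separate compound 4 from compound 1: this carbon accepts a formyl group with the amino group left in place, without a step beyond the scatter. No measurement shown here gives a reason for this result.

A single group at this carbon says little about the position as a whole, and a nitrile, a carboxylic acid or a longer chain there could give a different result. From the compounds shown here alone, whether the formyl group would behave the same way with chloro in place of methyl on the aryl ring also remains open.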